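Stripping both methyls from the amine of compound 3

The source may report more compounds than this note shows. Statements on the series, on what has been measured and on what is new or still open speak of the compounds shown alone.

In a functional assay on SW480 cells (Homo sapiens) for antiproliferative activity, read by MTT assay, with a stated time of 48 h (a higher number here means a weaker inhibitor, a lower number a stronger inhibitor), compound 1 `CCCCC(CCO)n1cnc2c(N)ncnc21` shows > 50000 nM as a limit, not a number.

In this assay compound 2 `CCCCCCCCCCCC(CCO)n1cnc2c(NC)ncnc21` gives 12800 nM and compound 3 `CCCCCCCCCCCC(CCO)n1cnc2c(N(C)C)ncnc21` gives 11800 nM within the scatter of it, so the two stand level. Compound 4 `CCCCCCCCCCCC(CCO)n1cnc2c(N)ncnc21` differs from compound 3 by carrying amino in place of dimethylamino on an aromatic carbon. For the measured compounds named here, one measured step bears on this: the methyl in place of hydrogen on that nitrogen, taken alone, changed little (a 1.1-fold lower number from compound 2 to compound 3 (0.04 log units; within the scatter)) and stayed within the scatter. The further loss of the last methyl has not been measured. A step of a 1.0-fold higher number from compound 3 to compound 4 (0.01 log units; within the scatter) is therefore expected, nothing beyond the scatter. In this assay the estimated value for compound 4 is 12000 nM with 6000 nM and 25000 nM as the expected ends of the range.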

Compound 4, half-maximal inhibitory concentration: 11600 nM
Compound 4: the middle estimate sits 1.0-fold (0.01 log units) above what was measured; measured number inside the range.
By their numbers in this assay, from the lowest: compounds 4, 3 and 2 (each within the scatter of the next). At a limit, above all of these: compound 1.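

Taking both methyls off this nitrogen, so that amino replaces dimethylamino on the aromatic carbon, leaves the number level (a 1.0-fold lower number from compound 3 to compound 4 (0.01 log units; within the scatter)), and taking off the single methyl does the same (a 1.1-fold lower number from compound 2 to compound 4 (0.04 log units; within the scatter)). With the amino group kept, the heptyl in place of hydrogen on the chain gives a step beyond the scatter (an at least 4.3-fold lower number from compound 1 to compound 4 (0.63 log units; beyond the scatter)). That step has only a lower bound, since compound 1 stands at a limit, not a number: the limit of > 50000 nM in this assay, at which 1 of the 4 values shown sits.

On these data alone, whether a benzyl group or a morpholine ring at this position would also leave the number level stays open. So does how an intermediate chain, such as octyl, would read.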